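The source may report more compounds than this note shows. Statements on the series, on what has been measured and on what is new or still open speak of the compounds shown alone.

In a functional assay on the whole organism for antagonist activity, with Mus musculus as the target (on this read-out lower numbers stand for an effect already at smaller amounts and higher numbers for an effect only at larger amounts of compound), three compounds of a shared core have been measured. Compound 1 `CC(=O)NCC(=O)Nc1ccc(Cl)cc1C(=O)c1ccccc1` gives 37 mg/kg in this assay. Compound 2 `CCC(=O)NCC(=O)N(C)c1ccc(Cl)cc1C(=O)c1ccccc1Cl` gives 1.4 mg/kg, the lowest of the two numbers measured, and its nearest neighbour is compound 1, which stands clearly higher. Compound 3 `CC(=O)NCC(=O)Nc1ccc(Cl)cc1C(=O)c1ccccc1Cl` gives only a limit of the assay, > 100 mg/kg. Going by the values given here, the one step between compounds that differ in a single place is an at least 2.7-fold higher number from compound 1 to compound 3 (0.43 log units; beyond the scatter); it involves (the limit of > 100 mg/kg in this assay, at which 1 of the 3 values shown sits), so only its lower bound is known.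

Compound 4 `CCCCC(=O)NCC(=O)N(C)c1ccc(Cl)cc1C(=O)c1ccccc1Cl` has not yet been measured. It differs from compound 2 by ethyl in place of hydrogen on a saturated chain carbon, two bonds along the chain from a carbonyl carbon. Among the compounds with values here, the measured step concerns a chloro on an aromatic carbon, not the saturated chain, so no measured step bears on this change, and the numbers for compound 1 and compound 2 are separated by several differences at once. The expected step is therefore a 1.4-fold higher number from compound 2 to compound 4 (0.15 log units; within the scatter), within the scatter. Compound 4 is estimated at 2 mg/kg in this assay, in the range from 0.7 mg/kg to 6 mg/kg.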

Compound 4, dose for half-maximal effect: 1.3 mg/kg
The estimate for compound 4 lay 1.5-fold (0.19 log units) above the measured number; the measured number falls inside the stated range.
By their numbers in this assay, from the lowest: compounds 4 and 2 (each within the scatter of the next); then compound 1. At a limit, above all of these: compound 3.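

Going by these compounds alone, this result is the first look at the saturated chain carbon two bonds along the chain from a carbonyl carbon, since the only earlier single-place step concerned a chloro on an aromatic carbon. In this assay, putting ethyl in place of hydrogen there gives a 1.1-fold lower number from compound 2 to compound 4 (0.03 log units; within the scatter), so the two compounds cannot be told apart, and this chain carbon can carry ethyl while the number stays in the low range set by compound 2. Nothing among the measurements shown explains why the ethyl leaves the number unchanged within the scatter.

This is a single step, so it shows only what ethyl does at this place. As far as these compounds go, whether a longer chain, a phenyl ring, an amine or a carboxylic acid on the same carbon would be accepted as well stays open.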